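The source may hold more compounds than are shown below. What is called first, only, known or untested is meant among the compounds shown, and "the series" means these compounds.

In an ADME assay on RAW264.7 cells (Mus musculus) for cytotoxicity, read by neutral red uptake, with a stated time of 24 h (a lower number here means that less compound is tolerated, a higher number that more compound is tolerated), compound 1, `O=C(CN1C(=O)CSC1=O)NOCc1ccccc1`, gives > 128000 nM, which is a limit of the assay and not a number. Compound 2, `CC(C(=O)NOCc1ccccc1)N1C(=O)CSC1=O`, gives in this assay the value > 128000 nM, again a limit. The change between them is methyl in place of hydrogen on a saturated chain carbon bound to an amide-type nitrogen in a ring and a carbonyl carbon, and the step it made is a step that the two limits leave unreadable from compound 1 to compound 2. Compound 3, `O=C(CN1C(=O)S/C(=C\c2ccc(C(F)(F)F)cc2)C1=O)NOCc1ccccc1`, gives in this assay the value > 128000 nM, which is also a limit. How the core of compound 3 differs from the core of compound 1 is not broken down here. Compound 4, `CC(C(=O)NOCc1ccccc1)N1C(=O)S/C(=C\c2ccc(C(F)(F)F)cc2)C1=O`, has not yet been measured in this assay. Within the data shown here, it differs from compound 3 by methyl in place of hydrogen on a saturated chain carbon bound to an amide-type nitrogen in a ring and a carbonyl carbon, the same change as the one from compound 1 to compound 2. Because all three measured compounds sit at the limit of > 128000 nM in this assay, at which 3 of the 3 values shown sit, the earlier step has no readable size, and the expected step that the limit leaves unreadable from compound 3 to compound 4 is accordingly expected to be small. Compound 4 is therefore expected in this assay to show 160000 nM, estimated between 90000 nM and 400000 nM, and most likely to be reported once more only as a limit.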

Compound 4, half-maximal cytotoxic concentration: > 128000 nM
Compound 4 gave a limit, no number (the forecaster's own chance of this, stated with the estimate: 85%); the middle value lies beyond the limit too.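

Compound 3 and compound 4 each give only a limit of the assay and not a number, so the step between them cannot be read, any more than the earlier one could: the limit of > 128000 nM in this assay, at which 4 of the 4 values shown sit.

The compounds shown leave open whether methyl in place of hydrogen changes anything in this assay at all, and at what concentration any of them would turn cytotoxic.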